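The compounds below may be only part of what the source reports. "The series", "measured", "known", "first", "only" and "open" are said of these compounds alone.

Measured in a functional assay on MCF7 cells (Homo sapiens) for antiproliferative activity, read by MTT assay, with a stated time of 48 h; on this read-out lower numbers stand for stronger inhibition and higher numbers for weaker inhibition:
- compound 1 `Fc1ccc2[nH]c(-c3cn(-c4ccccc4)nc3-c3ccccc3)nc2c1`: 2430 nM
- compound 2 `Brc1ccc2[nH]c(-c3cn(-c4ccccc4)nc3-c3ccccc3)nc2c1`: 830 nM
- compound 3 `FC(F)(F)c1ccc2[nH]c(-c3cn(-c4ccccc4)nc3-c3ccccc3)nc2c1`: 2660 nM

Compound 1 lies at the upper end of these numbers, with a 1.1-fold higher number from compound 1 to compound 3 (0.04 log units; within the scatter) and a 2.9-fold lower number from compound 1 to compound 2 (0.47 log units; beyond the scatter). Compound 4 `COc1ccc(-c2nn(-c3ccccc3)cc2-c2nc3cc(F)ccc3[nH]2)cc1` keeps the fluoro group and differs from compound 1 by methoxy in place of hydrogen on an aromatic carbon, which is methoxy in place of hydrogen on an aromatic carbon, phenyl to 4-methoxyphenyl. Among the measured compounds shown here, no measured step makes this change. The measured steps only exchange fluoro, bromo and trifluoromethyl, and the largest is a 3.2-fold higher number from compound 2 to compound 3 (0.51 log units; beyond the scatter). They therefore bear on size only and give no direction. A modest step in this assay is expected, with a weak lean to lower numbers. The expected change is a 1.4-fold lower number from compound 1 to compound 4 (0.16 log units; within the scatter). For compound 4 the estimate is 1700 nM, with an expected range of 500 nM to 5000 nM.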

Compound 4, half-maximal inhibitory concentration: 1510 nM
Estimate against measurement, compound 4: 1.1-fold (0.05 log units) above; measured number inside the range.
By their numbers in this assay, from the lowest: compounds 2, 4, 1 and 3 (each within the scatter of the next, the first and the last beyond it).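

In this assay, phenyl to 4-methoxyphenyl is the first change shown away from the place that carries fluoro, bromo or trifluoromethyl, and it gives a 1.6-fold lower number from compound 1 to compound 4 (0.21 log units; within the scatter) and so stays within the scatter. Methoxy on this aromatic carbon, para to a large group, is therefore tolerated in this single pair, with no shift that can be told from repeat variation. No measured evidence bears on why this is so. From the compounds shown here alone, whether an amine or a carboxylic acid at the same place would move the number beyond the scatter remains open.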